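Amide series: cytotoxicity notes toward compound 4

This account rests on a few compounds, and the source may have more. Where it says the series, first, only, none or still open, it means among the compounds named here.

Measured so far in an ADME assay on HepG2 2.2.15 cells (Homo sapiens) for cytotoxicity, read by MTT assay, with stated times of 48 h and 9 days; on this read-out lower numbers stand for higher toxicity in this test and higher numbers for lower toxicity in this test:

compound 1, `COc1ccc2c(=O)c(/C=C/C(=O)NCc3cccc(F)c3)coc2c1`: 475000 nM
compound 2, `COc1cccc(NC(=O)/C=C/c2coc3cc(OC)ccc3c2=O)c1`: 1130000 nM
compound 3, `COc1ccc2c(=O)c(/C=C/C(=O)Nc3cccc(C)c3)coc2c1`: 554000 nM

Compound 3 stands second highest of the three numbers. Its nearest neighbour is compound 1, the step being a 1.2-fold higher number from compound 1 to compound 3 (0.07 log units; within the scatter), which lies within the scatter. Its furthest neighbour is compound 2, the step being a 2.0-fold lower number from compound 2 to compound 3 (0.31 log units; beyond the scatter), a modest difference beyond the scatter.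

Compound 4, `COc1ccc2c(=O)c(/C=C/C(=O)NCc3ccc(F)cc3F)coc2c1`, is not yet measured. The change from compound 3 is 2,4-difluorobenzyl in place of 3-methylphenyl on an amide-type nitrogen. The step that bears most on it is a 1.2-fold higher number from compound 1 to compound 3 (0.07 log units; within the scatter), where a 3-fluorobenzyl on the amide-type nitrogen was exchanged for 3-methylphenyl without moving the number beyond the scatter. Among the compounds with values here, compound 4 returns to a benzyl-type amide, carrying 2,4-difluorobenzyl; the second fluorine has no precedent among the measured compounds, so no extra shift can be derived from the data. The expected step is therefore small, a 1.2-fold lower number from compound 3 to compound 4 (0.07 log units; within the scatter), in no direction beyond the scatter. Compound 4 is estimated at 470000 nM, with a range from 230000 nM to 950000 nM.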

Compound 4, half-maximal cytotoxic concentration: 79300 nM
The estimate for compound 4 lay 5.9-fold (0.77 log units) above the measured number; the measured number lies below the stated range.
By their numbers in this assay, from the lowest: compound 4; then compounds 1 and 3 (each within the scatter of the next); then compound 2.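

In this assay, within the data shown here, the group on the amide-type nitrogen can move the number well beyond the scatter, which the earlier compounds did not show at this size: 2,4-difluorophenyl in place of 3-fluorophenyl on the saturated chain carbon bound to that nitrogen gives a clear drop (a 6.0-fold lower number from compound 1 to compound 4 (0.78 log units; beyond the scatter)). The exchanges for the directly attached aryl groups also point to higher toxicity in this test with 2,4-difluorobenzyl (a 7.0-fold lower number from compound 3 to compound 4 (0.84 log units; beyond the scatter); a 14-fold lower number from compound 2 to compound 4 (1.15 log units; beyond the scatter)), the larger step coming against 3-methoxyphenyl. No measurement shown here explains the drop.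

The compounds shown do not separate the contribution of each fluorine within 2,4-difluorobenzyl. Also open, as far as these compounds go, is how an unsubstituted benzyl, a dichlorobenzyl or a longer chain such as phenethyl would read on this nitrogen.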